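Isopropyl in Place of 4-Aminobutyl on a Shared Core

A few compounds are considered here, and "the series" means these few. Any claim that something is new, unique, unknown or untested is made for them only; others in the source may bear on it.

Measured compounds:
compound 1 `NCCCCOc1ccc2c(=O)c(-c3ccc(O)cc3)coc2c1` — > 9000 nM
compound 2 `O=C(O)CCCCCOc1ccc2c(=O)cc(-c3ccc(O)cc3)oc2c1` — 7000 nM
compound 3 `CCCCC(Oc1ccc2c(=O)c(-c3ccc(O)cc3)coc2c1)C(=O)OCC` — >> 9000 nM

In an assay (Cricetulus griseus) for inhibition of Monoamine oxidase (Homo sapiens) (on this read-out higher numbers stand for weaker inhibition and lower numbers for stronger inhibition), compound 1 gives > 9000 nM, which is a limit of the assay and not a number. Compound 3 also gives only a limit in this assay, >> 9000 nM. Within the data shown here, compound 2 is the one compound with a number in this assay, 7000 nM. Among the measured compounds shown here, compound 1 therefore stands at the limit of > 9000 nM in this assay, at which 1 of the 3 values shown sits, and among the other two values one more sits at the limit of >> 9000 nM in this assay, at which 1 of the 3 values shown sits, so nothing here is a strong inhibitor and no step between measured compounds can be counted.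

Compound 4 `CC(C)Oc1ccc2c(=O)c(-c3ccc(O)cc3)coc2c1` differs from compound 1 in one place: isopropyl in place of 4-aminobutyl on an oxygen on an aromatic ring. For the measured compounds named here, with no measured step to lean on, the direction of this change is open. Since compound 1 is itself only a limit, a modest gain toward a measurable number is expected, though a step of any size beyond the scatter cannot be ruled out. The step from compound 1 to compound 4 is estimated as an at least 3.0-fold lower number from compound 1 to compound 4 (0.47 log units; beyond the scatter). For compound 4 in this assay the expected value is 3000 nM, within a range from 600 nM to 15000 nM.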

Compound 4, half-maximal inhibitory concentration: 200 nM
Compound 4: the middle estimate sits 15-fold (1.18 log units) above what was measured; the whole stated range lies above it.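

Isopropyl in place of 4-aminobutyl on an oxygen on an aromatic ring gives an at least 45-fold lower number from compound 1 to compound 4 (1.65 log units; beyond the scatter) in this assay, the first step that can be read in this series. The change yields a number well clear of the earlier read-outs, with compound 4 at 200 nM, so the group on this oxygen matters for inhibition on the shared core. The true size of the step remains unknown, since its starting point, compound 1, is only a limit: the limit of > 9000 nM in this assay, at which 1 of the 4 values shown sits.

The change removes the amine and replaces a straight chain with a branched one at the same time, and the compounds shown do not tell these two apart. From the compounds shown here alone, how a plain butyl chain, a methyl or a cyclopentyl on the same oxygen would read in this assay stays open.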